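Bromo to trifluoromethyl on the benzyl of compound 2

The source may hold more compounds than are shown below. What is called first, only, known or untested is meant among the compounds shown, and "the series" means these compounds.

Values so far in an ADME assay on Vero cells (Chlorocebus sabaeus) for cytotoxicity (a lower number here means that less compound is tolerated, a higher number that more compound is tolerated), for three compounds

- compound 1 `CC(=O)c1ccc(Nc2nc(NCCC(C)C)nc3[nH]cnc23)cc1` gives 85000 nM
- compound 2 `Cc1cc(OCc2ccc(F)cc2F)cc(=O)n1Cc1cn(Cc2cccc(Br)c2)nn1` gives 36000 nM
- compound 3 `OCCNc1nc(Nc2cccc(O)c2)c2nc[nH]c2n1` gives > 175000 nM

The reading for compound 3 (> 175000 nM) is a limit of the assay and not a number. Of the two true numbers, compound 2 (36000 nM) holds the lower, so less of it is tolerated than of compound 1 (85000 nM), and that gap lies beyond the usual scatter.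

Compound 4 `Cc1cc(OCc2ccc(F)cc2F)cc(=O)n1Cc1cn(Cc2cccc(C(F)(F)F)c2)nn1` has trifluoromethyl in place of bromo on an aromatic carbon, which turns the 3-bromobenzyl of compound 2 into a 3-(trifluoromethyl)benzyl. Going by the values given here, no two measured compounds differ in one place only, so this swap has no direct precedent. The nearest measured structure is compound 2 (36000 nM), and the expectation starts from that value. In this assay the expected change a 1.1-fold lower number from compound 2 to compound 4 (0.04 log units; within the scatter) stays within the scatter, with no direction favoured. Compound 4 is estimated at 33000 nM with an expected range (14000 nM to 75000 nM) around it.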

Compound 4, half-maximal cytotoxic concentration: 40000 nM
For compound 4 the middle estimate is 1.2-fold (0.08 log units) below the measured one, within the range that was stated.
By their numbers in this assay, from the lowest: compounds 2 and 4 (each within the scatter of the next); then compound 1. At a limit, above all of these: compound 3.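

In this assay, the 3-bromobenzyl of compound 2 and the 3-(trifluoromethyl)benzyl of compound 4 form the only pair shown that differs in one place, and the swap gives a 1.1-fold higher number from compound 2 to compound 4 (0.05 log units; within the scatter) on the six-membered aromatic ring. At this position, bromo and trifluoromethyl therefore read alike in this series, although 4 heavy atoms enter where 1 leaves. No measurement shown here bears on the cause of this outcome.

As far as these compounds go, whether an amine, a carboxylic acid or a nitrile at the same place would read alike remains open. Also open, from the compounds shown here alone, is whether a swap elsewhere on the core shared by compound 2 and compound 4 would shift the reading in this assay beyond the scatter.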